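A few compounds are considered here, and "the series" means these few. Any claim that something is new, unique, unknown or untested is made for them only; others in the source may bear on it.

Measured so far in an assay on LM cells for displacement of a labelled ligand from Neuropeptide Y receptor type 5 (Homo sapiens); on this read-out higher numbers stand for weaker inhibition and lower numbers for stronger inhibition:
Compound 1 `O=Cc1cccc(C2=NC(c3ccc(F)cc3)(c3ccc(F)cc3)CN2)c1`: 8.7 nM
Compound 2 `CN(C)c1cccc(C2=NC(c3ccc(F)cc3)(c3ccc(F)cc3)CN2)c1`: > 1000 nM, which is a limit of the assay rather than a number
Compound 3 `Fc1ccc(C2(c3ccc(F)cc3)CNC(c3ccccn3)=N2)cc1`: 160 nM

Of the two real numbers, compound 3 has the higher one, and so the weaker binding. Its nearest neighbour is compound 1, separated by an 18-fold higher number from compound 1 to compound 3 (1.26 log units; beyond the scatter). Compound 2 gives only a limit.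

The next compound, compound 4 `N#Cc1cc(C2=NC(c3ccc(F)cc3)(c3ccc(F)cc3)CN2)ccn1`, differs from compound 3 in one place: 2-cyanopyridin-4-yl in place of pyridin-2-yl on a carbon with a double bond to nitrogen.

Among the compounds with values here, two measured steps touch this position. The pyridin-2-yl ring is the weaker partner against the 3-formylphenyl group, as an 18-fold higher number from compound 1 to compound 3 (1.26 log units; beyond the scatter) shows, yet it does better than the 3-(dimethylamino)phenyl group, as an at least 6.2-fold lower number from compound 2 to compound 3 (0.79 log units; beyond the scatter) shows. Neither step tests a nitrile or a ring attached through its 4-position, so the direction is uncertain. The 2-cyanopyridin-4-yl ring does bring a second hydrogen-bond acceptor, as the formyl group of compound 1 does, and compound 1 gives 8.7 nM.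

A modest improvement is therefore expected, of about a 3.6-fold lower number from compound 3 to compound 4 (0.55 log units; beyond the scatter). Compound 4 is estimated at 45 nM, with a likely range from 8 nM to 250 nM.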

Compound 4, half-maximal inhibitory concentration: 4.8 nM
Beside the measured number, compound 4's estimate is 9.4-fold (0.97 log units) above it; measured number below the stated range.
By their numbers in this assay, from the lowest: compounds 4 and 1 (each within the scatter of the next); then compound 3. At a limit, above all of these: compound 2.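

In this assay, the carbon between two ring nitrogen atoms turns out to tolerate a pyridine ring far better than compound 3 suggested, with a 33-fold lower number from compound 3 to compound 4 (1.52 log units; beyond the scatter) once the pyridin-2-yl group gives way to 2-cyanopyridin-4-yl. Within the data shown here, the new ring also stands level with the 3-formylphenyl group, with a 1.8-fold lower number from compound 1 to compound 4 (0.26 log units; within the scatter), so at this position a formyl group on a benzene ring is not the only route to a value this low. The step of an at least 200-fold lower number from compound 2 to compound 4 (2.31 log units; beyond the scatter) starts from a limit of the assay and not from a number, so it gives only a minimum size for the gap to the 3-(dimethylamino)phenyl group: the limit of > 1000 nM in this assay, at which 1 of the 4 values shown sits.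

The nitrile and the change from a pyridin-2-yl to a pyridin-4-yl attachment arrive together, so the compounds shown cannot say which of the two carries the gain. On these data alone, how an unsubstituted pyridin-4-yl ring, or a pyridine ring bearing a carboxylic acid or a primary amide in place of the nitrile, would behave at this position also remains open.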